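One more methyl on the tert-butyl group

A few compounds are considered here, and "the series" means these few. Any claim that something is new, unique, unknown or untested is made for them only; others in the source may bear on it.

Measured in a functional assay on the whole organism with Rattus norvegicus as the target; on this read-out higher numbers stand for an effect only at larger amounts of compound and lower numbers for an effect already at smaller amounts:
Compound 1 `CC(C)c1ccc2nc(N)sc2c1`: > 10 mg/kg (a limit)
Compound 2 `CC(C)(C)c1ccc2nc(N)sc2c1`: 4 mg/kg

Among the compounds with values here, compound 2 gives the only true number in this assay, at 4 mg/kg. For compound 1 the reading is the limit of > 10 mg/kg in this assay, at which 1 of the 2 values shown sits, so it marks a limit and not a number.

Compound 3 `CCC(C)(C)c1ccc2nc(N)sc2c1` differs from compound 2 by methyl in place of hydrogen on a saturated chain carbon, two bonds along the chain from an aromatic carbon. The same difference reads tert-butyl to 1,1-dimethylpropyl.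

Within the data shown here, one measured step bears on this change, an at least 2.5-fold lower number from compound 1 to compound 2 (0.39 log units; beyond the scatter). That step also put methyl in place of hydrogen, but on a saturated chain carbon bound to an aromatic carbon, and it starts from a limit. With this single step as a guide, and with the new methyl placed differently, a small move in the same direction is expected, most likely not beyond the scatter. The expected change is a 1.3-fold lower number from compound 2 to compound 3 (0.12 log units; within the scatter). Compound 3 is estimated at 3 mg/kg, with an expected range from 1.2 mg/kg to 8 mg/kg.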

Compound 3, dose for half-maximal effect: > 10 mg/kg
Compound 3 ended at the assay's limit; the forecaster's own chance of this, stated with the estimate: 10%; at least 3.3-fold (0.52 log units) between middle value and limit.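

In this assay, extending tert-butyl to 1,1-dimethylpropyl gives an at least 2.5-fold higher number from compound 2 to compound 3 (0.39 log units; beyond the scatter), so a methyl on the saturated chain carbon two bonds along the chain from an aromatic carbon moves the read-out the opposite way from the earlier methyl change, an at least 2.5-fold lower number from compound 1 to compound 2 (0.39 log units; beyond the scatter). Of the three compounds shown, compound 2 therefore needs the smallest dose, and both the smaller isopropyl-bearing compound 1 and the larger 1,1-dimethylpropyl-bearing compound 3 fall away from it, so the effect does not simply follow the addition of methyl groups along this series. The step that joins compound 1 and compound 3 cannot be read, as both readings are limits and not numbers: the limit of > 10 mg/kg in this assay, at which 2 of the 3 values shown sit.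

Going by these compounds, how far compound 1 and compound 3 actually lie from compound 2 stays open, and so does any order between those two. Also open, on these data alone, is whether a cyclopropyl or a trifluoromethyl group in place of the tert-butyl would keep the effect at small doses in this assay, or whether a longer chain such as 1,1-dimethylbutyl would behave like the 1,1-dimethylpropyl group.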